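Carbamate chain length and maximal response

This account rests on a few compounds, and the source may have more. Where it says the series, first, only, none or still open, it means among the compounds named here.

Measured so far:
compound 1, `CC(C)OC(=O)N1CCC(Oc2cccc3c2CCN3c2ccc(S(C)(=O)=O)cc2)CC1`, 70%
compound 2, `CC(C)(C)OC(=O)N1CCC(Oc2cccc3c2CCN3c2ccc(S(C)(=O)=O)cc2)CC1`, 92%
compound 3, `COC(=O)N1CCC(Oc2ncnc3c2CCN3c2ccc(S(C)(=O)=O)cc2F)CC1`, 119%

All three numbers come from a functional assay on CHO-K1 cells with Glucose-dependent insulinotropic receptor (Homo sapiens) as the target, read by a luciferase reporter, with a stated time of 5 h; a lower number here means a smaller maximal response, a higher number a larger maximal response. Compound 1 and compound 2 share one core and differ by methyl in place of hydrogen on a saturated chain carbon bound to an oxygen next to a carbonyl group and two saturated chain carbons; the step is a number 22 percentage points higher from compound 1 to compound 2 (beyond the scatter). Compound 3 sits on a different core; the difference between the two cores is not broken down here. Compound 3 gives the highest of the three values, with both compound 2 and compound 1 lying beyond the scatter below it.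

Compound 4, `CCOC(=O)N1CCC(Oc2ncnc3c2CCN3c2ccc(S(C)(=O)=O)cc2F)CC1`, is not yet measured. It differs from compound 3 by methyl in place of hydrogen on a saturated chain carbon bound to an oxygen next to a carbonyl group. This is the same kind of change as that from compound 1 to compound 2, not the same: in the earlier pair the place also carries two saturated chain carbons, here it does not. The step from compound 3 to compound 4 is expected to be a number 9 percentage points higher from compound 3 to compound 4 (within the scatter), a smaller move than the earlier one, because compound 3 already starts from 119%. For compound 4 the estimated value is 128%, with the range 108% to 148%.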

Compound 4, largest response reached (reported as percent of maximum), in percent of the reference or control that the assay uses: 135%
Estimate against measurement, compound 4: 7 percentage points below; the measured number falls inside the stated range.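

In this assay, methyl in place of hydrogen on a saturated chain carbon bound to an oxygen next to a carbonyl group gives a number 16 percentage points higher from compound 3 to compound 4 (beyond the scatter), and the step has the same direction as the earlier one on the other core, with no difference in size that can be told apart: the same change on two cores in this assay, a number 22 percentage points higher (beyond the scatter) from compound 1 to compound 2 and a number 16 percentage points higher (beyond the scatter) from compound 3 to compound 4, 6 percentage points apart, within the scatter of two such steps

Within these two pairs, the change therefore carries from one core to the other in both direction and size. Going by these compounds alone, this does not establish a general rule: there are only two pairs, the carbon in the earlier pair also carries two saturated chain carbons while the one in the later pair does not, and neither step says why the response rises.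

On these data alone, whether a longer chain, such as propoxycarbonyl or butoxycarbonyl, extends the rise on the core of compound 4 remains open. Also open, as far as these compounds go, is how an amine in place of the carbamate oxygen would behave on either core.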